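This account rests on a few compounds, and the source may have more. Where it says the series, first, only, none or still open, it means among the compounds named here.

Three compounds sharing one core have been examined in a functional assay on SMMC-7721 cells (Homo sapiens) for cytotoxicity, read by MTT assay, with a stated time of 72 h (on this read-out lower numbers stand for stronger inhibition and higher numbers for weaker inhibition), and all of them carry the same pair of chlorinated rings on the core, differing only in the group attached at the double-bonded chain carbon.

Compound 1 `O=C1C(=Cc2ccc(O)cc2)C(=O)N(c2ccc(Cl)cc2)N1c1ccc(Cl)cc1` carries a 4-hydroxyphenyl there, and in this assay compound 1 gives 20600 nM. Within the data shown here, that is the only number among the three; the other two results are limits of the assay. Compound 2 `COc1ccc(C=C2C(=O)N(c3ccc(Cl)cc3)N(c3ccc(Cl)cc3)C2=O)cc1` sits at the limit > 128000 nM. Compound 3 `O=C1C(=Cc2ccc(Cl)cc2Cl)C(=O)N(c2ccc(Cl)cc2)N1c1ccc(Cl)cc1` likewise sits at the limit > 128000 nM. The step of an at least 6.2-fold higher number from compound 1 to compound 2 (0.79 log units; beyond the scatter) and the step of an at least 6.2-fold higher number from compound 1 to compound 3 (0.79 log units; beyond the scatter) both move away from compound 1, which therefore stands at the strongest inhibition seen so far.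

Compound 4 `O=C1C(=Cc2ccc(F)cc2F)C(=O)N(c2ccc(Cl)cc2)N1c1ccc(Cl)cc1` has not yet been measured. 2,4-difluorophenyl in place of 4-hydroxyphenyl on a double-bonded chain carbon bound to a double-bonded ring carbon The closest guide is the step from compound 1 to compound 3, which also exchanges the 4-hydroxyphenyl for a dihalogenated ring, and the step from compound 1 to compound 2, which also removes the hydroxyl hydrogen; both of these gave higher numbers beyond the scatter, with two of the three results at the limit of > 128000 nM in this assay, at which 2 of the 3 values shown sit. A step in the same direction is therefore expected, a 5.3-fold higher number from compound 1 to compound 4 (0.73 log units; beyond the scatter). Compound 4 is estimated at 110000 nM, within 30000 nM to 400000 nM.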

Compound 4, half-maximal inhibitory concentration: 35800 nM
Estimate against measurement, compound 4: 3.1-fold (0.49 log units) above, and the stated range covers the measured number.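

In this assay, placing a 2,4-difluorophenyl instead of a 4-hydroxyphenyl on the double-bonded chain carbon gives a 1.7-fold higher number from compound 1 to compound 4 (0.24 log units; within the scatter), so compound 4 cannot be told apart from compound 1 even though its ring has no hydrogen-bond donor, which means that the hydroxyl group is not required for a measurable number at this place. The halogens also matter, since a dihalogenated ring alone does not decide the outcome: fluorine in place of chlorine gives an at least 3.5-fold lower number from compound 3 to compound 4 (0.55 log units; beyond the scatter), and the comparison with the methoxy compound gives an at least 3.5-fold lower number from compound 2 to compound 4 (0.55 log units; beyond the scatter). Compound 2 and compound 3 are limits of the assay rather than numbers, so these last two steps give only the smallest possible size, and the true gaps may be larger: the limit of > 128000 nM in this assay, at which 2 of the 4 values shown sit.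

On these data alone, whether a ring with a single fluorine, an amine or a carboxylic acid at this place would keep a measurable number remains open. The compounds shown also leave open how far the numbers would shift if the two 4-chlorophenyl groups on the shared core were replaced, for example by unsubstituted phenyl rings.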